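The compounds below may be only part of what the source reports. "The series", "measured", "known", "first", "only" and "open" are said of these compounds alone.

Measured in an ADME assay on microsomes from liver (Homo sapiens) for metabolic stability, read by LC-MS, using NADPH, with a stated time of 10 min, tested at 10 uM; a higher number here means that the compound lasts longer, a lower number that the compound disappears faster:
- Compound 1 `Nc1ncnc2c1c(Oc1cc(C(F)(F)F)ccn1)nn2[C@@H]1CCCC[C@H]1O`: > 2.41 h (a limit)
- Compound 2 `Nc1ncnc2c1c(Oc1cc(C(F)(F)F)ccn1)nn2C1CC1`: > 2.41 h (a limit)
- Compound 3 `Nc1ncnc2c1c(Oc1cc(C(F)(F)F)ccn1)nn2[C@H]1CC[C@@H](CO)CC1`: 1.6 h

Among the compounds with values here, compound 3 holds the only exact number here. Beside it stands (the limit of > 2.41 h in this assay, at which 2 of the 3 values shown sit).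

Compound 4 `Nc1ncnc2c1c(Oc1cc(C(F)(F)F)ccn1)nn2CC1CC1` carries cyclopropylmethyl in place of 4-(hydroxymethyl)cyclohexyl on an aromatic nitrogen.

Within the data shown here, two measured steps bear on this change: an at least 1.5-fold lower number from compound 2 to compound 3 (0.17 log units; that floor lies within the scatter), and an at least 1.5-fold lower number from compound 1 to compound 3 (0.17 log units; that floor lies within the scatter). Compound 2 carries the closest group, cyclopropyl, so its step, read backwards, suggests a modest rise, though none clearly beyond the scatter. The expected step is a 1.4-fold higher number from compound 3 to compound 4 (0.14 log units; within the scatter). For compound 4 the estimated half-life is 2.2 h, with an expected range from 1.1 h to 4 h.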

Compound 4, half-life: 1.87 h
Beside the measured number, compound 4's estimate is 1.2-fold (0.07 log units) above it; measured number inside the range.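

Cyclopropylmethyl has fewer heavy atoms than 4-(hydroxymethyl)cyclohexyl and no hydrogen-bond donor, yet this swap on the aromatic nitrogen gives a 1.2-fold higher number from compound 3 to compound 4 (0.07 log units; within the scatter), so the half-life stays level. Set against the other two groups, cyclopropylmethyl gives an at least 1.2-fold lower number from compound 2 to compound 4 (0.11 log units; that floor lies within the scatter) and an at least 1.2-fold lower number from compound 1 to compound 4 (0.11 log units; that floor lies within the scatter), so neither step shows a clear loss. Both of these steps start from a limit and not from a number: the limit of > 2.41 h in this assay, at which 2 of the 4 values shown sit.

From the compounds shown here alone, how far the half-life of compound 1 or compound 2 truly lies from that of compound 4 stays open. So does whether an amine, a carboxylic acid or a longer chain on this nitrogen would move the half-life beyond the scatter.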